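The compounds below may be only part of what the source reports. "The series", "measured", "known", "first", "only" and "open" are said of these compounds alone.

Working notes on the series. Within the data shown here, compound 1 `COc1nc(C2CCCCC2)ccc1[C@@H](c1ccccc1)[C@@](O)(CCN(C)C)c1cccc2ccccc12` carries a cyclohexyl group on the shared core; in a toxicity assay on HeLa cells (Homo sapiens) for cytotoxicity (on this read-out lower numbers stand for higher toxicity in this test and higher numbers for lower toxicity in this test), compound 1 gives 57.7 ug/mL, the only plain number in the set. Compound 2 `COc1nc(-c2ccccc2Cl)ccc1[C@@H](c1ccccc1)[C@@](O)(CCN(C)C)c1cccc2ccccc12` returns only a limit in this assay, > 64 ug/mL. The step of an at least 1.1-fold higher number from compound 1 to compound 2 (0.04 log units; that floor lies within the scatter) is therefore bounded on one side only, and the limit of > 64 ug/mL in this assay, at which 1 of the 2 values shown sits, marks where it sits. Compound 3 `COc1nc(-c2ccc(Cl)cc2)ccc1[C@@H](c1ccccc1)[C@@](O)(CCN(C)C)c1cccc2ccccc12` is the unmeasured analogue; it differs from compound 1 as follows: 4-chlorophenyl in place of cyclohexyl on an aromatic carbon. Among the measured compounds shown here, the only measured step that bears on this change is the one to compound 2, from which a change beyond the scatter cannot be read, so a 1.1-fold higher number from compound 1 to compound 3 (0.05 log units; within the scatter) is expected to be small and, if anything, toward a higher number in this assay. For compound 3 the estimate in this assay is 64 ug/mL, with a range from 40 ug/mL to 100 ug/mL.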

Compound 3, half-maximal cytotoxic concentration: > 64 ug/mL
Compound 3 gave a limit, no number; the forecaster's own chance of this, stated with the estimate: 55%; the middle value sits exactly at the limit.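

With 4-chlorophenyl in place of cyclohexyl, this assay shows an at least 1.1-fold higher number from compound 1 to compound 3 (0.04 log units; that floor lies within the scatter), so a second chlorophenyl group at this position on the shared core now gives a result with only a lower bound. The step between compound 2 and compound 3 cannot be read, because both results are limits and neither gives a number: the limit of > 64 ug/mL in this assay, at which 2 of the 3 values shown sit. No change beyond the scatter can therefore be read for either chlorophenyl group, and nothing separates the 2-chloro from the 4-chloro placement.

From the compounds shown here alone, whether any group at this position differs from cyclohexyl by more than the scatter stays open. Also open, going by these compounds, is how unsubstituted phenyl, an amine, a carboxylic acid or a longer alkyl chain at the same place would read in this assay.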